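Adding a Second Methoxy Group

This account rests on a few compounds, and the source may have more. Where it says the series, first, only, none or still open, it means among the compounds named here.

Measured so far:
compound 1, `COc1ccc(N)c(C2=NN(C(=O)C3CCCC3)CC2)c1` — 1.85%
compound 2, `Nc1ccccc1C1=NN(C(=O)CCc2ccccc2)CC1` — 5.64%
compound 3, `COc1ccc(N)c(C2=NN(C(=O)CCc3ccccc3)CC2)c1` — 21.2%

In an assay on isolated protein for inhibition of Nitric oxide synthase, inducible (Homo sapiens), with a stated time of 30 min, tested at 1 mM (on this read-out lower numbers stand for less inhibition and higher numbers for more inhibition at the one concentration tested (going by the name of the read-out)), compound 3 stands highest of the three. Its margin over compound 2 is a number 15.6 percentage points higher from compound 2 to compound 3 (beyond the scatter) and its margin over compound 1 is a number 19.4 percentage points higher from compound 1 to compound 3 (beyond the scatter); both steps are beyond the scatter, so compound 3 has the highest number of the measured set in this assay.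

Compound 4, `COc1cc(N)c(C2=NN(C(=O)CCc3ccccc3)CC2)cc1OC`, differs from compound 3 in one place: methoxy in place of hydrogen on an aromatic carbon. For the measured compounds named here, of the measured steps, only the one from compound 2 to compound 3 is of the same kind, a methoxy in place of hydrogen on an aromatic carbon, though at a different aromatic carbon of the same ring; that step gave a number 15.6 percentage points higher from compound 2 to compound 3 (beyond the scatter) in this assay. The step from compound 1 to compound 3 concerns the group on the carbonyl carbon and bears less directly on this change.

With a single precedent, a further rise is expected but a smaller one is reasonable, because the step of a number 15.6 percentage points higher from compound 2 to compound 3 (beyond the scatter) need not repeat at another position. The step from compound 3 to compound 4 is therefore estimated as a number 8.8 percentage points higher from compound 3 to compound 4 (within the scatter), and compound 4 is expected to give about 30%, within 8% to 50%.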

Compound 4, a percentage reported as inhibition, at one concentration (the size of the read-out at that concentration, not a potency): 23.7%
The estimate for compound 4 lay 6.3 percentage points above the measured number, within the range that was stated.
By their numbers in this assay, from the lowest: compounds 1 and 2 (each within the scatter of the next); then compounds 3 and 4 (each within the scatter of the next).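

In this assay, a methoxy on the aromatic carbon that is ortho to a methoxy group, meta to an amino group and para to a large group gives a number 2.5 percentage points higher from compound 3 to compound 4 (within the scatter) and so cannot be told apart from hydrogen at this position. The same exchange of hydrogen for methoxy at a different carbon of the ring gave a number 15.6 percentage points higher from compound 2 to compound 3 (beyond the scatter) and stood beyond the scatter, so on this ring the printed outcome of the change depends on which carbon carries it, as far as these two steps show. Nothing among the data shown explains why the second methoxy leaves the number within the scatter.

The compounds shown leave open whether a methoxy at this position would read the same with no methoxy on the other carbon, since every pair here has it added to compound 3 alone. They also leave open whether a different group at this carbon, such as a hydroxy, an ethoxy or a fluorine atom, would move the number beyond the scatter when the phenethyl group stays on the carbonyl.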